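A Five-Membered Ring Swap on a Weak Aortic Inhibitor

The compounds below may be only part of what the source reports. "The series", "measured", "known", "first", "only" and "open" are said of these compounds alone.

Measured compounds:
compound 1, `COc1nc(-c2nc3ccccc3n2C)cc(-c2ccc(F)cc2)c1C#N`: 343000 nM
compound 2, `COc1nc(-c2nc3ccccc3n2C)cc(-c2cccs2)c1C#N`: 312000 nM

In a functional assay on aorta (Rattus norvegicus, strain Wister) (a higher number here means a weaker inhibitor, a lower number a stronger inhibitor), compound 1 gives 343000 nM, and compound 2 gives 312000 nM. For the measured compounds named here, the only step between measured compounds, a 1.1-fold lower number from compound 1 to compound 2 (0.04 log units; within the scatter), is within the scatter. Compound 2 thus shows the smaller of the two numbers on paper, but the gap to compound 1 lies within the scatter, so the two cannot be told apart in this assay.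

Compound 3, `COc1nc(-c2nc3ccccc3n2C)cc(-c2ccc(C)o2)c1C#N`, has not been measured. It differs from compound 2 in one place: 5-methylfuran-2-yl in place of thiophen-2-yl on an aromatic carbon. Going by the values given here, the one measured step that bears on this change is the earlier swap of the group at the same position, a 1.1-fold lower number from compound 1 to compound 2 (0.04 log units; within the scatter), which did not move the number beyond the scatter. On that basis no shift beyond the scatter in this assay is expected in either direction. For compound 3 the expected step is a 1.0-fold lower number from compound 2 to compound 3 (0.02 log units; within the scatter). Compound 3 is estimated at 300000 nM, with a range from 150000 nM to 600000 nM.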

Compound 3, half-maximal inhibitory concentration: 283000 nM
Estimate against measurement, compound 3: 1.1-fold (0.03 log units) above; low and high end bracket the measured number.
By their numbers in this assay, from the lowest: compounds 3, 2 and 1 (each within the scatter of the next).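

In this assay the position opposite the ring nitrogen has now taken three different groups, and the new swap, a 1.1-fold lower number from compound 2 to compound 3 (0.04 log units; within the scatter), again leaves the read-out unresolved, although 5-methylfuran-2-yl brings a ring oxygen and 6 heavy atoms where thiophen-2-yl had a ring sulfur and 5. The wider comparison, a 1.2-fold lower number from compound 1 to compound 3 (0.08 log units; within the scatter), shows that 4-fluorophenyl and 5-methylfuran-2-yl cannot be told apart here either, so all three compounds lie within the scatter of one another and this place has not yet shown any response to a change of aromatic group. Nothing on hand explains why these swaps leave the number within the scatter.

On these data alone, all three groups at this place are aromatic rings, so it remains open whether an amine such as morpholine, a carboxylic acid or a longer alkyl chain there would move the number beyond the scatter. It also remains open whether the nitrile and methoxy groups on the shared core matter at all, since both stay the same throughout the compounds shown.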